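The compounds below may be only part of what the source reports. "The series", "measured", "known", "first", "only" and "open" are said of these compounds alone.

Series notes. Compound 1 `O=C(Nc1ccc(C(=O)O)c(O)c1)c1cccc(N2C(=O)CCS2(=O)=O)c1` gives 44% in an assay on isolated protein for inhibition of NAD-dependent protein deacylase sirtuin-6 (Homo sapiens), read by fluorescence, tested at 200 uM; on this read-out lower numbers stand for less inhibition and higher numbers for more inhibition at the one concentration tested (going by the name of the read-out). Compound 2 `O=C(Nc1ccc(C(=O)O)c(O)c1)c1cccc(NC(=O)c2ccco2)c1` gives 62% in this assay. Compound 3 `O=C(Nc1ccc(C(=O)O)c(O)c1)c1ccc(N2C(=O)CCS2(=O)=O)cc1` gives 100% in this assay, the highest of the three. The step of a number 18 percentage points higher from compound 1 to compound 2 (beyond the scatter) goes with the change (a group of 8 heavy atoms (5 carbon, 1 nitrogen, 2 oxygen; one five-membered aromatic ring with 1 hetero atom) in place of a group of 8 heavy atoms (3 carbon, 1 nitrogen, 3 oxygen, 1 sulfur; one five-membered non-aromatic ring with 2 hetero atoms), on an aromatic carbon). The cores of compound 1 and compound 3 hold the same atoms joined differently; that difference is not broken down here. Compound 4 `O=C(Nc1ccc(C(=O)O)c(O)c1)c1ccc(NC(=O)c2ccco2)cc1` is not yet measured; it differs from compound 3 by a group of 8 heavy atoms (5 carbon, 1 nitrogen, 2 oxygen; one five-membered aromatic ring with 1 hetero atom) in place of a group of 8 heavy atoms (3 carbon, 1 nitrogen, 3 oxygen, 1 sulfur; one five-membered non-aromatic ring with 2 hetero atoms), on an aromatic carbon, the same kind of change as from compound 1 to compound 2, though here para to a large group rather than meta. A step of about the earlier size cannot show, since compound 3 already stands at the top of the read-out with 100%; compound 4 is therefore expected to stay near it, with an estimated a number 5 percentage points lower from compound 3 to compound 4 (within the scatter). Estimate for compound 4: 95%, range 78% to 100%.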

Compound 4, a percentage reported as inhibition, at one concentration (the size of the read-out at that concentration, not a potency): 100%
Estimate against measurement, compound 4: 5 percentage points below, and the stated range covers the measured number.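

In this assay the change to ((furan-2-yl)carbonyl)amino gives no change at the digits printed from compound 3 to compound 4 (within the scatter), so the step seen on the first core does not reappear on this one: the same change on two cores in this assay, a number 18 percentage points higher (beyond the scatter) from compound 1 to compound 2 and no change at the digits printed (within the scatter) from compound 3 to compound 4, 18 percentage points apart, beyond the scatter of two such steps Compound 3 and compound 4 both stand at the top of the read-out, so this step has no room to rise and cannot show whether the change adds anything on this core. The gap between the steps therefore shows that the size of the gain did not carry over as a read-out, not that the change is without effect on the core of compound 3.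

Still open, going by these compounds, is how compound 3 and compound 4 would rank at a lower tested concentration, where neither stands at the top. Also open, on these data alone, is how an amine or a thiophene-2-carbonylamino group would read in place of ((furan-2-yl)carbonyl)amino on either core.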